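Working notes: from bromo to trifluoromethyl

A few compounds are considered here, and "the series" means these few. Any claim that something is new, unique, unknown or untested is made for them only; others in the source may bear on it.

- compound 1 `O=S(=O)(c1ccccc1)n1c(-c2cn(-c3ccccc3)nc2-c2ccc(C(F)(F)F)cc2)nc2ccccc21`: 560 nM
- compound 2 `O=[N+]([O-])c1ccc(S(=O)(=O)n2c(-c3cn(-c4ccccc4)nc3-c3ccc(C(F)(F)F)cc3)nc3ccccc32)cc1`: 950 nM
- compound 3 `O=S(=O)(c1ccc(Br)cc1)n1c(-c2cn(-c3ccccc3)nc2-c2ccc(C(F)(F)F)cc2)nc2ccccc21`: 1860 nM

All three values come from a functional assay on HeLa cells (Homo sapiens) for antiproliferative activity, read by MTT assay, with a stated time of 24 h; a higher number here means a weaker inhibitor, a lower number a stronger inhibitor. Two steps fix the place of the bromo compound: a 3.3-fold higher number from compound 1 to compound 3 (0.52 log units; beyond the scatter), and a 2.0-fold higher number from compound 2 to compound 3 (0.29 log units; within the scatter).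

Compound 4 `O=S(=O)(c1ccc(C(F)(F)F)cc1)n1c(-c2cn(-c3ccccc3)nc2-c2ccc(C(F)(F)F)cc2)nc2ccccc21` has trifluoromethyl in place of bromo on an aromatic carbon. Within the data shown here, no measured step contains trifluoromethyl. The nearest evidence is the other group changes on that aromatic carbon: a 1.7-fold higher number from compound 1 to compound 2 (0.23 log units; within the scatter), a 2.0-fold higher number from compound 2 to compound 3 (0.29 log units; within the scatter), and a 3.3-fold higher number from compound 1 to compound 3 (0.52 log units; beyond the scatter). These steps are small, so no step beyond the scatter is expected in this assay, with a lean toward a lower number. The expected change is a 1.4-fold lower number from compound 3 to compound 4 (0.16 log units; within the scatter). Compound 4 is estimated at 1300 nM, with an expected range of 600 nM to 2800 nM.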

Compound 4, half-maximal inhibitory concentration: 970 nM
For compound 4 the middle estimate is 1.3-fold (0.13 log units) above the measured one, within the range that was stated.
By their numbers in this assay, from the lowest: compounds 1, 2, 4 and 3 (each within the scatter of the next, the first and the last beyond it).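

In this assay the steps of a 1.9-fold lower number from compound 3 to compound 4 (0.28 log units; within the scatter) and a 1.0-fold higher number from compound 2 to compound 4 (0.01 log units; within the scatter) and a 1.7-fold higher number from compound 1 to compound 4 (0.24 log units; within the scatter) all lie within the scatter. Trifluoromethyl therefore stands apart from none of hydrogen, nitro or bromo on this aromatic carbon, whereas the bromo compound 3 and the hydrogen compound 1 remain the only pair separated beyond the scatter. Nothing available here accounts for the difference between bromo and trifluoromethyl at this position.

The compounds shown carry only hydrogen, nitro, bromo or trifluoromethyl at this position. As far as these compounds go, how an amine or a carboxylic acid on the same carbon would read remains open.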